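Aryl Triazole Amides Held at the Assay Ceiling

The compounds below may be only part of what the source reports. "The series", "measured", "known", "first", "only" and "open" are said of these compounds alone.

Compound 1 `CC(C)n1ncc2c(C(=O)NCc3cn(-c4cccc(F)c4)nn3)cccc21` gives in a functional assay on MCF7 cells (Homo sapiens) for inhibition, read by MTT assay, with a stated time of 72 h (a lower number here means a stronger inhibitor, a higher number a weaker inhibitor), a value that is a limit of the assay, > 40000 nM.
Compound 2 `Cc1cccc(-n2cc(CNC(=O)c3cccc4c3cnn4C(C)C)nn2)c1` gives in this assay likewise a limit of the assay, > 40000 nM.

Among the compounds with values here, compound 2 therefore stands at the ceiling of this assay, and the only other value shown sits there too (the limit of > 40000 nM in this assay, at which 2 of the 2 values shown sit). Within the data shown here, the single measured step, a step that the two limits leave unreadable from compound 1 to compound 2, is thus unreadable in size and direction. Compound 3 `CCc1ccc(-n2cc(CNC(=O)c3cccc4c3cnn4C(C)C)nn2)cc1` differs from compound 2 by 4-ethylphenyl in place of 3-methylphenyl on an aromatic nitrogen. No readable step bears on this change, so there is no ground to expect compound 3 to move away from the ceiling, and the step from compound 2 is expected to be a step that the limit leaves unreadable from compound 2 to compound 3. Compound 3 is estimated at 60000 nM in this assay, within a range from 20000 nM to 200000 nM, most probably reported again as a limit.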

Compound 3, half-maximal inhibitory concentration: > 40000 nM
Compound 3: only a limit was reported; the forecaster's own chance of this, stated with the estimate: 85%; the middle value is on the limit's open side.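

In this assay compound 3 gives a limit of the assay, > 40000 nM. Its steps from compound 1 and from compound 2 therefore cannot be read in size or direction: the limit of > 40000 nM in this assay, at which 3 of the 3 values shown sit. The compounds shown leave open whether any group on the aromatic nitrogen brings a readable value in this assay.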